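One Fluorine Added to Compound 3

The source may hold more compounds than are shown below. What is called first, only, known or untested is meant among the compounds shown, and "the series" means these compounds.

Compound 1 `C=C1CCC(c2csc(/C=C(\C)C(N)=O)c2)CC1` gives 18000 nM in a functional assay on HO8910 cells (Homo sapiens) for cytotoxicity, read by CCK-8 assay, with a stated time of 24 h; a lower number here means a stronger inhibitor, a higher number a weaker inhibitor.
Compound 2 `C/C(=C\c1cc(-c2ccc(C)cc2)co1)C(N)=O` gives 24200 nM in this assay.
Compound 3 `C/C(=C\c1cc(-c2cccnc2)co1)C(N)=O` gives 8640 nM in this assay.

Among these three, compound 3 gives the lowest number, and both compound 1 and compound 2 lie above it by more than the usual scatter. Compound 4 `C/C(=C\c1cc(-c2ccc(F)nc2)co1)C(N)=O` differs from compound 3 in one place: fluoro in place of hydrogen on an aromatic carbon. Within the data shown here, no measured pair in this set shows such a swap, so there is nothing to copy from. A single fluorine is a small change, and the expectation here is a step of no clear size or direction, likely within the scatter. Compound 4 is expected to give about 8000 nM in this assay, with a range from 3500 nM to 20000 nM. The expected step is a 1.1-fold lower number from compound 3 to compound 4 (0.03 log units; within the scatter), essentially none beyond the scatter.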

Compound 4, half-maximal inhibitory concentration: 30000 nM
Compound 4: the middle estimate sits 3.8-fold (0.57 log units) below what was measured; measured number above the stated range.
By their numbers in this assay, from the lowest: compound 3; then compounds 1, 2 and 4 (each within the scatter of the next).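

In this assay placing fluoro on the aromatic carbon next to the ring nitrogen, para to a large group, gives a 3.5-fold higher number from compound 3 to compound 4 (0.54 log units; beyond the scatter) and so shows that this carbon does not tolerate every small change. Among these compounds, the earlier compounds offered no one-place swap, so this is the first step that can be read for this ring position. No measurement shown here accounts for the step. Going by these compounds, whether a chloro group or an amine on the same carbon would also raise the number remains open, as does the effect of fluoro on other carbons of this ring.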